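The source may hold more compounds than are shown below. What is called first, only, known or untested is meant among the compounds shown, and "the series" means these compounds.

In a physicochemical assay for solubility, in phosphate buffer, at pH 7.4 (on this read-out lower numbers stand for lower solubility and higher numbers for higher solubility), compound 1, `CCONC(=N)c1ccc2[nH]c(-c3cccc(-c4ccccc4O)c3O)cc2c1`, gives 43000 nM. Compound 2, `CC(C)OC(=O)NC(=N)c1ccc2[nH]c(-c3cccc(-c4ccccc4O)c3O)cc2c1`, carries an isopropoxycarbonyl in place of the ethoxy on the amine nitrogen of compound 1. For compound 2 this assay reports only a limit, < 10000 nM, so its place on the scale is known just as a ceiling (the limit of < 10000 nM in this assay, at which 1 of the 2 values shown sits). Within the data shown here, the one measured step, an at least 4.3-fold lower number from compound 1 to compound 2 (0.63 log units; beyond the scatter), is accordingly itself a bound rather than a fixed size. Compound 3, `N/C(=N/C(=O)OCC(Cl)(Cl)Cl)c1ccc2[nH]c(-c3cccc(-c4ccccc4O)c3O)cc2c1`, has not yet been measured in this assay. It differs from compound 2 in one place: a group of 11 heavy atoms (4 carbon, 2 nitrogen, 2 oxygen, 3 chlorine; no ring) in place of a group of 9 heavy atoms (5 carbon, 2 nitrogen, 2 oxygen; no ring), on an aromatic carbon. Among the measured compounds shown here, the only measured step that bears on this change is the one already described, which at least modestly lowered the number when isopropoxycarbonyl replaced the ethoxy; compound 3 keeps a group of the same kind at that nitrogen, now carrying chlorines in place of the isopropyl. For the measured compounds named here, no measured step tracks that second change, so the expectation rests on compound 2 staying where it is. Compound 3 is therefore expected to give 5000 nM, within a range from 1000 nM to 15000 nM, which means an expected step that the limit leaves unreadable from compound 2 to compound 3 from the limit, with a real chance that this assay again reports only a limit.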

Compound 3, solubility: < 10000 nM
Compound 3: only a limit was reported; the forecaster's own chance of this, stated with the estimate: 70%; the middle value lies beyond the limit too.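

Replacing the ethoxy-bearing group on the aromatic carbon with the chlorine-carrying group gives, in this assay, an at least 4.3-fold lower number from compound 1 to compound 3 (0.63 log units; beyond the scatter). Among these compounds, two different groups at this place, the isopropoxycarbonyl of compound 2 and the chlorine-carrying group of compound 3, now sit on the low side of compound 1, where the earlier compounds offered only one. The step between compound 2 and compound 3 cannot be read, so neither can be ranked against the other, and the reading for compound 3 is itself only a limit, which adds a second compound at the same ceiling: the limit of < 10000 nM in this assay, at which 2 of the 3 values shown sit.

The compounds shown leave open how far under that ceiling compound 2 and compound 3 actually lie, and whether the lower numbers go with the carbonyl that both carry or with what is attached to it. They also do not tell whether a simple amine or a carboxylic acid at this place, or a longer chain on the carbonyl, would keep the number closer to that of compound 1.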